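The source may report more compounds than this note shows. Statements on the series, on what has been measured and on what is new or still open speak of the compounds shown alone.

Working notes on the series. Compound 1 `CC(=O)Oc1ccc(C(=O)Nc2cc3ccc(OCC4CCN(C)C4)c(C)c3oc2=O)cc1CC=C(C)C` gives 1880 nM in a functional assay on MCF7 cells (Homo sapiens) for antiproliferative activity; on this read-out lower numbers stand for stronger inhibition and higher numbers for weaker inhibition. Compound 2 `CC(=O)Oc1ccc(C(=O)Nc2cc3ccc(OCCC4CCCCN4)c(C)c3oc2=O)cc1CC=C(C)C` gives 710 nM in this assay, the difference being a 2.6-fold lower number from compound 1 to compound 2 (0.42 log units; beyond the scatter). Compound 3 `CC(C)=CCc1cc(C(=O)Nc2cc3ccc(OCCCNC(C)C)c(C)c3oc2=O)ccc1O` gives 740 nM in this assay and stands second highest of the three numbers: within the scatter of compound 2, and separated from compound 1 by a step beyond the scatter.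

Compound 4 `CC(C)=CCc1cc(C(=O)Nc2cc3ccc(OCCCN(C)Cc4ccccc4)c(C)c3oc2=O)ccc1O` differs from compound 3 by benzyl(methyl)amino in place of isopropylamino on a saturated chain carbon, three bonds along the chain from an oxygen on an aromatic ring. For the measured compounds named here, the only measured step at the amine end, a 2.6-fold lower number from compound 1 to compound 2 (0.42 log units; beyond the scatter), sits at a different place on the chain and exchanges one ring amine for another; no measured pair tests a benzyl group or the loss of the amine hydrogen, so the direction of the present change is not anchored. Given that the one related step was modest, the step is expected to be a 1.1-fold lower number from compound 3 to compound 4 (0.06 log units; within the scatter) at most, without a firm direction. Compound 4 is therefore estimated at 650 nM in this assay, within 250 nM to 1800 nM.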

Compound 4, half-maximal inhibitory concentration: 11500 nM
For compound 4 the middle estimate is 18-fold (1.25 log units) below the measured one, outside the stated range (above it).
By their numbers in this assay, from the lowest: compounds 2 and 3 (each within the scatter of the next); then compound 1; then compound 4.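

At the amine end of the chain, benzyl(methyl)amino in place of isopropylamino gives a 16-fold higher number from compound 3 to compound 4 (1.19 log units; beyond the scatter) in this assay, so this position is sensitive to the change, with a much larger step than a 2.6-fold lower number from compound 1 to compound 2 (0.42 log units; beyond the scatter). The change adds one six-membered aromatic ring and takes the hydrogen-bond donor count from 1 to 0, and this single step cannot separate the two. No measurement shown here accounts for the loss of activity.

Open, from the compounds shown here alone, is which of the two differences carries the step: benzylamino would keep the amine hydrogen along with the ring, while dimethylamino would remove that hydrogen without adding a ring. Also open, going by these compounds, is whether the step holds on a chain longer than the 3-(benzyl(methyl)amino)propyl chain.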